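The compounds below may be only part of what the source reports. "The series", "measured", "known", "first", "only" and "open" are said of these compounds alone.

Measured so far:
compound 1 `CN(C)c1ccc(NC(=O)c2csc(Cc3c(Cl)cccc3Cl)n2)cc1` — 1270 nM in an assay on CHO cells, read by calcium flux; on this read-out lower numbers stand for stronger inhibition and higher numbers for weaker inhibition.
compound 2 `O=C(Nc1ccc(Br)cn1)c1csc(Cc2c(Cl)cccc2Cl)n1` — > 4000 nM, a limit of this assay and not a number.
compound 3 `O=C(Nc1ccc(C(F)(F)F)cc1)c1csc(Oc2c(Cl)cccc2Cl)n1` — 1280 nM.

Compound 3 stands at the highest of the two numbers; its nearest neighbour is compound 1, whose value lies within the scatter of it, so no order is drawn between the two. Compound 2 sits at the limit of > 4000 nM in this assay, at which 1 of the 3 values shown sits.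

Compound 4, `O=C(Nc1ccc(C(F)(F)F)cc1)c1csc(Nc2ccccc2Cl)n1`, differs from compound 3 by (2-chlorophenyl)amino in place of 2,6-dichlorophenoxy on an aromatic carbon. Within the data shown here, no step between measured compounds bears on this change, so the expectation rests on the values of compound 3 alone. In this assay a step toward a higher number, of about the size of the scatter, is expected: a 1.6-fold higher number from compound 3 to compound 4 (0.19 log units; within the scatter). Compound 4 is estimated at 2000 nM, with a range from 600 nM to 6000 nM.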

Compound 4, half-maximal inhibitory concentration: 1410 nM
Beside the measured number, compound 4's estimate is 1.4-fold (0.15 log units) above it; low and high end bracket the measured number.
By their numbers in this assay, from the lowest: compounds 1, 3 and 4 (each within the scatter of the next). At a limit, above all of these: compound 2.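

The exchange of 2,6-dichlorophenoxy for (2-chlorophenyl)amino on this aromatic carbon gives a 1.1-fold higher number from compound 3 to compound 4 (0.04 log units; within the scatter) in this assay. Among these compounds, this place therefore tolerates a change of linking atom, the loss of one chlorine and the gain of one hydrogen-bond donor without a step beyond the scatter, though the single step cannot separate these parts of the change. No available evidence bears on this step.

From the compounds shown here alone, whether (2,6-dichlorophenyl)amino would behave the same remains open, and this would separate the linking atom from the second chlorine. Also open, going by these compounds, is how an aliphatic amine or a carboxylic acid would read at this place.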